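The source may hold more compounds than are shown below. What is called first, only, known or untested is meant among the compounds shown, and "the series" means these compounds.

Compound 2, `O=C(Nc1cccc(C(=O)O/N=C2\CCCc3noc(-c4ccc(F)cc4)c32)c1)c1cccc(F)c1`, is one of two measured members of a small set built on a shared core. In a functional assay on MDA-MB-231 cells (Homo sapiens) for antiproliferative activity, read by MTT assay, with a stated time of 72 h (on this read-out lower numbers stand for stronger inhibition and higher numbers for weaker inhibition), compound 2 returns only a limit, > 25000 nM, and not a number. Compound 1, `O=C(Nc1ccccc1C(=O)O/N=C1\CCCc2onc(-c3ccc(F)cc3)c21)c1cccc(F)c1`, likewise gives only a limit in this assay, > 25000 nM. Within the data shown here, what the numbers show is the limit of > 25000 nM in this assay, at which 2 of the 2 values shown sit, so compound 2 stands alongside compound 1 at the edge of what this assay can report, and no step between measured compounds can be drawn.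

Compound 3, `O=C(Nc1cccc(C(=O)O/N=C2\CCCc3noc(-c4cccc(F)c4)c32)c1)c1cccc(F)c1`, differs from compound 2 in one place: 3-fluorophenyl in place of 4-fluorophenyl on an aromatic carbon. With both known values resting at the limit, the numbers offer no direction for this change, and compound 3 is expected to stay at or near that limit. The expected step is a step that the limit leaves unreadable from compound 2 to compound 3. Compound 3 is therefore estimated at 30000 nM, within a range from 8000 nM to 100000 nM, and most probably reported again only as a limit.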

Compound 3, half-maximal inhibitory concentration: 9300 nM
Beside the measured number, compound 3's estimate is 3.2-fold (0.51 log units) above it; the range from low to high includes it.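

Among these compounds, compound 3 is the first compound here to give a number rather than a limit, which shows that this aromatic carbon next to the ring oxygen can register a change in the aryl group. In this assay, 3-fluorophenyl in place of 4-fluorophenyl gives an at least 2.6-fold lower number from compound 2 to compound 3 (0.42 log units; beyond the scatter), although the two groups have the same atoms, joined differently. The true size of the step stays unknown because the value of compound 2 is only a limit, not a number: the limit of > 25000 nM in this assay, at which 2 of the 3 values shown sit.

The compounds shown leave open whether an unsubstituted phenyl, a 2-fluorophenyl or a 3-chlorophenyl on this carbon would lower the number further. They also leave open whether 3-fluorophenyl would have a similar effect on the core of compound 1.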